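Phenyl for cyclohexyl on the amide nitrogen across two cores

This account rests on a few compounds, and the source may have more. Where it says the series, first, only, none or still open, it means among the compounds named here.

Compound 1 `N#C/C(=C\c1ccoc1)C(=O)NC1CCCCC1` carries a cyclohexyl group on the amide-type nitrogen; in a functional assay on the whole organism (strain CD1) for inhibition, with Mus musculus as the target, with stated times of 15 min and 20 min, at a dose of 10 mg/kg by the subcutaneous route (a higher number here means more inhibition at the dose given (going by the name of the read-out), a lower number less inhibition), compound 1 gives 0%. Compound 2 `N#C/C(=C\c1ccoc1)C(=O)Nc1ccccc1` differs from it by phenyl in place of cyclohexyl on an amide-type nitrogen, and in this assay compound 2 gives 48%, so that a number 48 percentage points higher from compound 1 to compound 2 (beyond the scatter). Compound 3 `N#C/C(=C\c1cc2ccccc2[nH]1)C(=O)NC1CCCCC1` keeps the cyclohexyl group of compound 1 on a different core; the difference between the two cores is not broken down here. In this assay compound 3 gives 45%, which lies within the scatter of the value of compound 2 and beyond the scatter of the value of compound 1.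

Compound 4 `N#C/C(=C\c1cc2ccccc2[nH]1)C(=O)Nc1ccccc1` is not yet measured. It stands to compound 3 as compound 2 stands to compound 1: phenyl in place of cyclohexyl on an amide-type nitrogen. The place of the change reads the same in both pairs, an amide-type nitrogen whose other neighbour is the carbonyl carbon, so this is the same change, occurring twice in the set. Going by the values given here, its one measured instance made a large upward step. Compound 3 starts from a number close to that of compound 2 and higher than the number of compound 1, so a step of the full earlier size is not expected to carry over. The step from compound 3 to compound 4 is estimated as a number 25 percentage points higher from compound 3 to compound 4 (beyond the scatter), smaller than the earlier one. For compound 4 in this assay a value of 70% is expected. The expected range for compound 4 runs from 40% to 95%. This rests on compound 3 standing at 45% and on a number 48 percentage points higher from compound 1 to compound 2 (beyond the scatter).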

Compound 4, a percentage reported as inhibition, in the whole organism at one dose (the size of the read-out at that dose, not a potency): 52%
Compound 4: the middle estimate sits 18 percentage points above what was measured, and the stated range covers the measured number.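

In this assay, phenyl in place of cyclohexyl on an amide-type nitrogen gives a number 7 percentage points higher from compound 3 to compound 4 (within the scatter), so on the core of compound 3 this assay does not separate the two groups. The change therefore does not transfer in size from one core to the other, and the large step on the core of compound 1 cannot be taken as a general gain for phenyl in this series: the same change on two cores in this assay, a number 48 percentage points higher (beyond the scatter) from compound 1 to compound 2 and a number 7 percentage points higher (within the scatter) from compound 3 to compound 4, 41 percentage points apart, beyond the scatter of two such steps. This shows that the outcome of the change depends on the core in these two pairs, but with a single pair per core, and a read-out taken at one dose rather than a potency, it does not show which feature of the cores is responsible, nor how the two cores would rank with any other group on that nitrogen.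

The compounds shown leave open how either core responds to other groups on the amide nitrogen, such as a benzyl group, a longer alkyl chain, or a phenyl carrying a carboxylic acid or an amine. They also leave open whether a third core would follow the pair of compound 1 and compound 2 or the pair of compound 3 and compound 4.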